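The source may hold more compounds than are shown below. What is called first, only, known or untested is meant among the compounds shown, and "the series" means these compounds.

Compound 1 `CCC(=O)Nc1ccc(-c2nc3cc(C(F)(F)F)ccc3[nH]2)cc1`: in an ADME assay on Vero cells (Chlorocebus sabaeus) for cytotoxicity (a higher number here means that more compound is tolerated, a lower number that less compound is tolerated), compound 1 gives > 100000 nM, which is a limit of the assay rather than a number.
Compound 2 `CCN(CC)CC(=O)Nc1ccc(-c2nc3cc(C(F)(F)F)ccc3[nH]2)cc1`: in this assay compound 2 gives 24000 nM.
Compound 3 `O=[N+]([O-])c1ccc(-c2nc3ccccc3[nH]2)c([N+](=O)[O-])c1`: in this assay compound 3 gives > 100000 nM, again a limit of the assay.

Compound 3 thus sits at the limit of > 100000 nM in this assay, at which 2 of the 3 values shown sit, so only a bound is known for it, not a number. Compound 4 `O=[N+]([O-])c1ccccc1-c1nc2ccccc2[nH]1` differs from compound 3 by hydrogen in place of nitro on an aromatic carbon. For the measured compounds named here, the only measured step, an at least 4.1-fold lower number from compound 1 to compound 2 (0.61 log units; beyond the scatter), concerns a different change on a different core and does not bear on removing a nitro group, so it gives no guidance here. With compound 3 already at the limit, no shift beyond the scatter is expected, and the estimated step of a number no higher from compound 3 to compound 4 (the limit leaves the size open) is centred on no change. Compound 4 is therefore expected to give about 100000 nM, within 30000 nM to 300000 nM, most likely reported once more as a limit.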

Compound 4, half-maximal cytotoxic concentration: > 100000 nM
Compound 4: a limit, no number; the forecaster's own chance of this, stated with the estimate: 70%; the middle value sits exactly at the limit.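

Compound 3 and compound 4 both give a limit of the assay rather than a number, so no step can be read between them: the limit of > 100000 nM in this assay, at which 3 of the 4 values shown sit.

Going by these compounds, whether hydrogen in place of nitro changes the tolerated concentration in this assay at all stays open.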